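The compounds below may be only part of what the source reports. "The series", "measured", "known", "first", "only" and "open" are said of these compounds alone.

Measured in an ADME assay on the whole organism (Canis lupus familiaris, strain Beagle) for pharmacokinetics, read by LC-MS, with a stated time of 7 h; on this read-out higher numbers stand for wider distribution into tissues and lower numbers for narrower distribution:
compound 1 `CNC(=O)c1cc(C(=O)N[C@H]2[C@@H]3COC[C@@H]32)c([C@@H](C)c2ccccc2)o1` gives 1.1 L/kg
compound 2 `CNC(=O)c1cc(C(=O)N[C@H]2CC[C@H](O)CC2)n([C@@H](C)c2ccccc2)n1` gives 0.9 L/kg
compound 3 `CNC(=O)c1cc(C(=O)N[C@H]2CC[C@H](O)CC2)c([C@@H](C)c2ccccc2)o1` gives 0.8 L/kg

Compound 2 stands second highest of the three numbers, but its gaps to compound 3 and to compound 1 are both within the scatter, so the three are not separated. Among the measured compounds shown here, the one step between measured compounds, a 1.4-fold lower number from compound 1 to compound 3 (0.14 log units; within the scatter), exchanges the group on the amide-type nitrogen and is itself within the scatter. Compound 4 `CNC(=O)c1cc(C(=O)N[C@H]2CC[C@H](OC)CC2)n([C@@H](C)c2ccccc2)n1` differs from compound 2 by methyl in place of hydrogen on an oxygen on a saturated carbon. No measured pair tests a change at this oxygen; the step shown concerns a different part of the molecule and does not bear on it. With all three measured values lying within the scatter of each other in this assay, no step beyond the scatter is expected in either direction. Compound 4 is therefore estimated at 1 L/kg, range 0.6 L/kg to 1.7 L/kg, an expected step of a 1.1-fold higher number from compound 2 to compound 4 (0.05 log units; within the scatter).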

Compound 4, volume of distribution at steady state: 2.1 L/kg
For compound 4 the middle estimate is 2.1-fold (0.32 log units) below the measured one; the whole stated range lies below it.
By their numbers in this assay, from the lowest: compounds 3, 2, 1 and 4 (each within the scatter of the next, the first and the last beyond it).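

In this assay, hydroxy to methoxy on the saturated ring carbon gives a 2.3-fold higher number from compound 2 to compound 4 (0.37 log units; beyond the scatter) and so is a change this read-out can separate, whereas the exchange of the whole group on the amide-type nitrogen gave only a 1.4-fold lower number from compound 1 to compound 3 (0.14 log units; within the scatter) and stayed unresolved. The oxygen of the 4-hydroxycyclohexyl group is thus a position where a single methyl registers. Nothing available bears on the reason for this step. As far as these compounds go, whether the same change carries over to the core of compound 3 remains open. So does the outcome with ethoxy or an amine at this place.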